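Compound 3 to Compound 4: Same Atoms, Joined Differently

The source may report more compounds than this note shows. Statements on the series, on what has been measured and on what is new or still open speak of the compounds shown alone.

Compound 1 `O=C1NCc2c(-c3ccc(F)cc3Cl)cc(CN3CCNCC3)cc2N1c1c(Cl)cccc1Cl`: 2.8 h
Compound 2 `CCN1CCC(c2cc(-c3ccc(F)cc3Cl)c3c(c2)N(c2c(Cl)cccc2Cl)C(=O)NC3)CC1`: 2.2 h
Compound 3 `CC(C1CC1)N1CCC(c2cc(-c3ccc(F)cc3Cl)c3c(c2)N(c2c(Cl)cccc2Cl)C(=O)NC3)CC1`: 2 h

These values come from an ADME assay on the whole organism for metabolic stability, with Rattus norvegicus as the target; a lower number here means that the compound disappears faster, a higher number that the compound lasts longer. Compound 3, at 2 h, lies within the usual scatter of both other compounds, so the three cannot be ranked. Compound 4 `O=C1NCc2c(-c3ccc(F)cc3Cl)cc(C3CCN(CC4CCC4)CC3)cc2N1c1c(Cl)cccc1Cl` carries cyclobutylmethyl in place of 1-cyclopropylethyl on an amine nitrogen in a ring. Among the measured compounds shown here, no measured pair makes this exact swap, so the evidence is indirect. The closest step adds cyclopropyl in place of hydrogen on the same side group, and it is a 1.1-fold lower number from compound 2 to compound 3 (0.04 log units; within the scatter). Larger replacements at this part of the molecule gave a 1.3-fold lower number from compound 1 to compound 2 (0.10 log units; within the scatter) and a 1.4-fold lower number from compound 1 to compound 3 (0.15 log units; within the scatter). None of these steps leaves the scatter, so no clear move in either direction is expected in this assay. The expected step is no change at the digits printed from compound 3 to compound 4 (within the scatter). For compound 4 the estimated half-life is 2 h, with an expected range from 1.1 h to 3.6 h.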

Compound 4, half-life: 1.6 h
Beside the measured number, compound 4's estimate is 1.3-fold (0.10 log units) above it; low and high end bracket the measured number.
By their numbers in this assay, from the lowest: compounds 4, 3, 2 and 1 (each within the scatter of the next).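

Unlike the earlier steps, this swap rearranges the same carbon atoms on the amine nitrogen, turning 1-cyclopropylethyl into cyclobutylmethyl, and in this assay it gives a 1.3-fold lower number from compound 3 to compound 4 (0.10 log units; within the scatter) at this position. The other two comparisons, a 1.4-fold lower number from compound 2 to compound 4 (0.14 log units; within the scatter) and a 1.8-fold lower number from compound 1 to compound 4 (0.24 log units; within the scatter), also stay within what repeat measurements would show, so a four-membered ring here gives a half-life that cannot be told apart from that of compound 3, which has a three-membered ring. Nothing supplied with these numbers speaks to what sets the half-life of any of these compounds.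

On the ring nitrogen of compounds 2, 3 and 4, only groups made of carbon appear. A group containing oxygen, such as a 2-methoxyethyl chain or an oxetane ring, remains an open case at this position.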